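A few compounds are considered here, and "the series" means these few. Any claim that something is new, unique, unknown or untested is made for them only; others in the source may bear on it.

Of the compounds shown here, two carry numbers so far. Compound 1 `ClCc1ccc(Cn2cnc3c(Cl)ncnc32)cc1` is the weaker of the pair in a functional assay on EKVX cells (Homo sapiens) for cytotoxicity, read by sulforhodamine B assay, with a stated time of 48 h; a lower number here means a stronger inhibitor of growth, a higher number a weaker inhibitor of growth: compound 1 gives 6920 nM, the highest of the two numbers recorded. Compound 2 `ClCc1cccc(Cn2cnc3c(Cl)nc(Cl)nc32)c1` in this assay gives 2310 nM, a lower number, and the gap lies beyond the usual scatter. Compound 2 differs from compound 1 in more than one place, so no single step can be read from that pair; the two values stand as they are.

Compound 3 `Nc1nc(Cl)c2ncn(Cc3ccc(CCl)cc3)c2n1` awaits measurement. It differs from compound 1 in one place: amino in place of hydrogen on an aromatic carbon. The amino enters on an aromatic carbon of the shared core, between two ring nitrogen atoms, meta to a chloro group. Among the measured compounds shown here, no measured pair shows this change, so nothing in the present data fixes its direction or size. The working expectation is a step of a 1.4-fold lower number from compound 1 to compound 3 (0.14 log units; within the scatter) in this assay, small and within the usual scatter in either direction. Compound 3 is thus expected to give about 5000 nM in this assay, with a range from 1500 nM to 15000 nM.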

Compound 3, concentration for total growth inhibition: 7240 nM
Beside the measured number, compound 3's estimate is 1.4-fold (0.16 log units) below it, and the stated range covers the measured number.
By their numbers in this assay, from the lowest: compound 2; then compounds 1 and 3 (each within the scatter of the next).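

In this assay, amino in place of hydrogen on an aromatic carbon of the shared core, between two ring nitrogen atoms, gives a 1.0-fold higher number from compound 1 to compound 3 (0.02 log units; within the scatter) and is the only step among the compounds shown that can be read in one place. The opening pair could say nothing about this carbon, whereas this step shows that compound 1 and compound 3 cannot be told apart in this read-out. At this position, with the rest of compound 1 held constant, the amino group therefore brings no readable change in growth inhibition on these cells, and the data offer no explanation for this.

From the compounds shown here alone, whether this carbon is equally undemanding for other groups remains open, as a dimethylamino group, a methoxy group or a carboxylic acid there could give a different result. Going by these compounds, it is also open whether the amino step would read the same if the chloro group on the shared core were replaced by an amine, or if the chloromethyl group gave way to a longer chain.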